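From Compound 2 to Compound 3: Hydroxy Replaced by Hydrogen

The source may hold more compounds than are shown below. What is called first, only, known or untested is meant among the compounds shown, and "the series" means these compounds.

Compound 1 `CCC(CC)CN1CCC(C(=O)Nc2cc(Cl)c(N)cc2OC)CC1`: in a functional assay on the whole organism for antagonist activity, with Mus musculus as the target (a lower number here means that less compound is needed, a higher number that more compound is needed for the effect), compound 1 gives > 10 mg/kg, which is a limit of the assay and not a number.
Compound 2 `COc1cc(N)c(Cl)cc1NC(=O)C1CCN(Cc2ccc(O)cc2)CC1`: in this assay compound 2 gives > 8 mg/kg, again a limit of the assay rather than a number.

Compound 2 therefore stands only at a limit; no measured number places it. Going by the values given here, the single measured step, a step that the two limits leave unreadable from compound 1 to compound 2, runs between two limits, the limit of > 10 mg/kg in this assay, at which 1 of the 2 values shown sits, and (the limit of > 8 mg/kg in this assay, at which 1 of the 2 values shown sits), so its size cannot be read.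

Compound 3 `COc1cc(N)c(Cl)cc1NC(=O)C1CCN(Cc2ccccc2)CC1` differs from compound 2 by hydrogen in place of hydroxy on an aromatic carbon. Among the compounds with values here, no measured step bears on this change, and the one step known is unreadable, so the step that the limit leaves unreadable from compound 2 to compound 3 is an expectation without a measured anchor. Compound 3 is expected to give about 10 mg/kg, within 3 mg/kg to 30 mg/kg, with a real chance that the assay again reports only a limit.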

Compound 3, dose for half-maximal effect: 0.5 mg/kg
Beside the measured number, compound 3's estimate is 20-fold (1.30 log units) above it; the measured number lies below the stated range.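

Going by these compounds alone, compound 3 gives the first real number in this assay, so this series now has a measured anchor rather than only limits. Hydrogen in place of hydroxy on the aromatic carbon gives an at least 16-fold lower number from compound 2 to compound 3 (1.20 log units; beyond the scatter), which shows that this place on the ring, para to a large group, strongly affects the dose needed, and that the change of a single oxygen-bearing group is enough to show it. Phenyl in place of pentan-3-yl gives an at least 20-fold lower number from compound 1 to compound 3 (1.30 log units; beyond the scatter), while the step between the two limits cannot be read, so an aromatic ring helps here only when it lacks the hydroxy.

From the compounds shown here alone, whether an amine or a methoxy at this same place would keep the low dose of compound 3 remains open. The data shown offer no explanation for the size of this step.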